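Swapping the dichlorobenzyl isomer on compound 2

The source may report more compounds than this note shows. Statements on the series, on what has been measured and on what is new or still open speak of the compounds shown alone.

Measured in (a functional assay on CNE2Z cells (Homo sapiens) for inhibition, read by MTT assay, with a stated time of 72 h; a higher number here means a weaker inhibitor, a lower number a stronger inhibitor):
- compound 1 (`C=CCc1ccc(OCc2ccc(Cl)cc2Cl)c(-c2ccc(OCc3ccc(Cl)cc3Cl)c(CC=C)c2)c1`): (> 50000 nM)
- compound 2 (`C=CCc1ccc(O)c(-c2ccc(OCc3c(Cl)cccc3Cl)c(CC=C)c2)c1`): (16400 nM)

The entry for compound 1 (> 50000 nM) is a limit and not a number. For the measured compounds named here, compound 2 (16400 nM) holds the only numeric value so far. Compound 3 (`C=CCc1ccc(O)c(-c2ccc(OCc3ccc(Cl)cc3Cl)c(CC=C)c2)c1`) is not yet measured and differs from compound 2 (2,4-dichlorophenyl in place of 2,6-dichlorophenyl on a saturated chain carbon bound to an oxygen on an aromatic ring), with 2,4-dichlorophenyl in place of 2,6-dichlorophenyl on a saturated chain carbon bound to an oxygen on an aromatic ring. Going by the values given here, no measured step bears on this change, so no step beyond the usual scatter is expected in (this assay). The expected step is small (a 1.1-fold lower number from compound 2 to compound 3 (0.04 log units; within the scatter)). The estimate for compound 3 is (15000 nM), with an expected range from (6000 nM) to (38000 nM).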

Compound 3, half-maximal inhibitory concentration: 11300 nM
For compound 3 the middle estimate is 1.3-fold (0.12 log units) above the measured one; measured number inside the range.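

In this assay 2,4-dichlorophenyl in place of 2,6-dichlorophenyl on a saturated chain carbon bound to an oxygen on an aromatic ring gives a 1.5-fold lower number from compound 2 to compound 3 (0.16 log units; within the scatter) and so does not tell the two isomers apart. Hydrogen in place of 2,4-dichlorobenzyl on an oxygen on an aromatic ring gives an at least 4.4-fold lower number from compound 1 to compound 3 (0.64 log units; beyond the scatter) and is the only step so far beyond the scatter. The entry for compound 1 is a limit and not a number: the limit of > 50000 nM in this assay, at which 1 of the 3 values shown sits.

Open, from the compounds shown here alone, is how this position responds to groups other than dichlorobenzyl, such as an amine or a carboxylic acid on a longer chain. Also open, going by these compounds, is whether hydrogen in place of the 2,6-dichlorobenzyl of compound 2 would change the number.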